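A few compounds are considered here, and "the series" means these few. Any claim that something is new, unique, unknown or untested is made for them only; others in the source may bear on it.

Measured so far in an ADME assay on the whole organism for pharmacokinetics, with Rattus norvegicus as the target, at a dose of 5 mg/kg by the oral route; a lower number here means less compound in the circulation, a higher number more compound in the circulation at the dose given:
- compound 1 `Cc1nc(-c2nc[nH]n2)ccc1-c1cnc2c(n1)N([C@H]1CC[C@@H](O)CC1)C(=O)CN2`: 30 nM
- compound 2 `O=C1CN(CCC2CCOCC2)c2nc(-c3ccc(-c4nc[nH]n4)nc3)cnc2N1`: 20 nM

Going by the values given here, on these numbers, compound 1 at 30 nM and compound 2 at 20 nM lie within the scatter of each other, so compound 1 stands level with the only other measured compound. Among the compounds with values here, neither compound is separated from the other in this assay, and the two differ in more than one place, so the pair gives no measured step to carry forward.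

Not yet measured is compound 3 `CO[C@H]1CC[C@H](N2C(=O)CNc3ncc(-c4ccc(-c5nc[nH]n5)nc4C)nc32)CC1`. It keeps the core of compound 1 and carries 4-methoxycyclohexyl in place of 4-hydroxycyclohexyl on an amide-type nitrogen in a ring.

Within the data shown here, the data hold no measured example of this change, so the expectation is tentative. A small rise in this assay is expected, of a size that may not clear the usual scatter, starting from compound 1 at 30 nM. The estimated change is a 1.7-fold higher number from compound 1 to compound 3 (0.22 log units; within the scatter). For compound 3 the expected value is 50 nM, with an estimated range of 15 nM to 200 nM.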

Compound 3, maximal plasma concentration: 840 nM
The estimate for compound 3 lay 17-fold (1.23 log units) below the measured number, outside the stated range (above it).
By their numbers in this assay, from the lowest: compounds 2 and 1 (each within the scatter of the next); then compound 3.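

At the substituent on the amide-type nitrogen in a ring, exchanging 4-hydroxycyclohexyl for 4-methoxycyclohexyl gives, in this assay, a 28-fold higher number from compound 1 to compound 3 (1.45 log units; beyond the scatter), so this position is far from silent in this read-out. The change is small when counted: the six-membered ring of carbon only and the 2 defined stereocentres stay, while the entering group adds one carbon and has 0 hydrogen-bond donors in place of 1. Going by these compounds alone, this is the first one-place step, as compound 1 and compound 2 differ in more than one place and lie within the scatter of each other.

Still open, going by these compounds, is whether the rise is specific to the methoxy group or also appears with an ethoxy group, an amine or a carboxylic acid in its place on the cyclohexyl ring, and whether the same exchange would behave alike on another core, since the whole reading rests on a single pair at one oral dose in one species. Nothing measured here accounts for the size of this step.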